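A Larger Pyridyl Group on the Shared Core

A few compounds are considered here, and "the series" means these few. Any claim that something is new, unique, unknown or untested is made for them only; others in the source may bear on it.

Compound 2 `Cc1nn(-c2nc(-c3ccc(Cl)c(Cl)c3)c(SC(C)C)s2)c(C(=O)O)c1-c1ccncc1` gives 5900 nM in a functional assay on BJAB cells (Homo sapiens) for antiproliferative activity, with a stated time of 4 days; on this read-out higher numbers stand for an effect only at larger amounts of compound and lower numbers for an effect already at smaller amounts; this is the higher of the two numbers recorded, with compound 1 `Cc1ccc(-c2c(C)nn(-c3nc(-c4ccc(Cl)c(Cl)c4)c(SC(C)C)s3)c2C(=O)O)cc1` nearest at 3800 nM, a gap that lies within the scatter. Among the measured compounds shown here, the only measured step, a 1.6-fold higher number from compound 1 to compound 2 (0.19 log units; within the scatter), exchanged one six-membered aromatic ring for another on the same aromatic carbon of the core and stayed within the scatter. Compound 3 `CCOc1ncccc1-c1c(C)nn(-c2nc(-c3ccc(Cl)c(Cl)c3)c(SC(C)C)s2)c1C(=O)O` carries the change (2-ethoxypyridin-3-yl in place of pyridin-4-yl on an aromatic carbon). For the measured compounds named here, because a 1.6-fold higher number from compound 1 to compound 2 (0.19 log units; within the scatter) showed that a different aromatic group at this position left the number essentially unchanged, the step to compound 3 is expected to be small as well, with no clear direction beyond the scatter, although the entering group itself has no precedent among the measured compounds. The estimate for compound 3 is therefore 5000 nM, within 1800 nM to 14000 nM, which is expected to mean a 1.2-fold lower number from compound 2 to compound 3 (0.07 log units; within the scatter).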

Compound 3, half-maximal effective concentration: 11000 nM
Compound 3: middle estimate off by 2.2-fold (0.34 log units), on the low side, and the stated range covers the measured number.
By their numbers in this assay, from the lowest: compounds 1, 2 and 3 (each within the scatter of the next, the first and the last beyond it).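

In this assay the larger 2-ethoxypyridin-3-yl group, taking the place of pyridin-4-yl, gives a 1.9-fold higher number from compound 2 to compound 3 (0.27 log units; within the scatter) and so adds nothing that can be told from repeat scatter on its own. Set against 4-methylphenyl on the same aromatic carbon, the same group gives a 2.9-fold higher number from compound 1 to compound 3 (0.46 log units; beyond the scatter) and is thus the only step shown at this position to pass beyond the scatter, though only modestly. No measurement offered here accounts for this shift in the number.

Going by these compounds, whether the ethoxy chain or the pyridine ring itself carries the step stays open, since a plain pyridin-3-yl group or a 2-methoxypyridin-3-yl group would be needed to separate the two. On these data alone, how an amine on that ring, or a non-aromatic group such as cyclohexyl on this carbon, would read is equally open.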